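Changing the group on the carbonyl of compound 2

The source may hold more compounds than are shown below. What is called first, only, known or untested is meant among the compounds shown, and "the series" means these compounds.

In an ADME assay on cells (Hepatocyte, Mus musculus) for metabolic stability, read by LC-MS, with a stated time of 10 min, tested at 1 uM (a higher number here means faster removal of the compound, a lower number slower removal), two compounds have values so far:
- compound 1 `O=C(NCc1ccc(S(=O)(=O)c2cccc(C(F)(F)F)c2)cc1)c1cc2cnccc2[nH]1` gives 60 mL/min/kg
- compound 2 `O=C(NCc1ccc(S(=O)(=O)c2cc(F)cc(F)c2)cc1)c1cc2cnccc2[nH]1` gives 70 mL/min/kg

Compound 2 stands level with compound 1, as the two numbers lie within the scatter of each other. Compound 3 `O=C(NCc1ccc(S(=O)(=O)c2cc(F)cc(F)c2)cc1)c1cnc2nccn2c1`, not yet measured, carries a group of 9 heavy atoms (6 carbon, 3 nitrogen; one five-membered aromatic ring with 2 hetero atoms, one six-membered aromatic ring with 2 hetero atoms) in place of a group of 9 heavy atoms (7 carbon, 2 nitrogen; one five-membered aromatic ring with 1 hetero atom, one six-membered aromatic ring with 1 hetero atom), on a carbonyl carbon and is otherwise the same as compound 2. Among the measured compounds shown here, the only measured step, a 1.2-fold higher number from compound 1 to compound 2 (0.07 log units; within the scatter), lies within the scatter and sits on a sulfonyl sulfur, so it offers little guidance here. For the measured compounds named here, no measured step touches the group on the carbonyl carbon, and the data support no firm direction. In this assay the estimated step, a 1.3-fold lower number from compound 2 to compound 3 (0.10 log units; within the scatter), is therefore expected to stay within the scatter. Compound 3 is expected at 55 mL/min/kg with 28 mL/min/kg and 85 mL/min/kg as the ends of the estimated range.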

Compound 3, clearance: 74 mL/min/kg
Compound 3: middle estimate off by 1.3-fold (0.13 log units), on the low side, and the stated range covers the measured number.
By their numbers in this assay, from the lowest: compounds 1, 2 and 3 (each within the scatter of the next).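

In this assay, the exchange on the carbonyl carbon, now measured for the only time here, gives a 1.1-fold higher number from compound 2 to compound 3 (0.02 log units; within the scatter). The entering group has 0 hydrogen-bond donors and 3 hydrogen-bond acceptors in place of 1 hydrogen-bond donor and 1 hydrogen-bond acceptor, so this difference in counts comes with no change beyond the scatter in this pair, just as the change on the sulfonyl sulfur gave only a 1.2-fold higher number from compound 1 to compound 2 (0.07 log units; within the scatter). Nothing available here explains why the number holds in this pair.

Going by these compounds, it remains open whether a plain phenyl, a pyridine or a longer alkyl chain on the carbonyl carbon would move the number beyond the scatter. Also open, on these data alone, is whether the same exchange would behave alike with 3-(trifluoromethyl)phenyl on the sulfonyl sulfur.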